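Same benzyl swap on a second core: expected permeability

The compounds below may be only part of what the source reports. "The series", "measured", "known", "first", "only" and "open" are said of these compounds alone.

Compound 1 `COc1ccc(F)cc1CNCCCNc1ccnc2cc(Oc3cccc(N(C)C)c3)ccc12` gives 317 10^-6 cm/s in an ADME assay for permeability, using PAMPA, with a stated time of 30 min, at pH 7.4; a higher number here means that the compound crosses the layer faster, a lower number that the compound crosses the layer more slowly.
Compound 2 `COc1cccc(CNCCCNc2ccnc3cc(Oc4cccc(N(C)C)c4)ccc23)c1O` gives 317 10^-6 cm/s in this assay.
Compound 3 `COc1cccc(CNCCCNc2ccnc3cc(-c4cc(C(F)(F)F)cc(C(F)(F)F)c4)ccc23)c1O` gives 237 10^-6 cm/s in this assay.

Compound 2 and compound 1 share one core and differ in a single spot: 5-fluoro-2-methoxyphenyl in place of 2-hydroxy-3-methoxyphenyl on a saturated chain carbon bound to an amine nitrogen. That change produced no change at the digits printed from compound 2 to compound 1 (within the scatter). Compound 3 is built on a different core; how the two cores differ is not broken down here. Compound 4 `COc1ccc(F)cc1CNCCCNc1ccnc2cc(-c3cc(C(F)(F)F)cc(C(F)(F)F)c3)ccc12` has not yet been measured, and it arises from compound 3 by the same change: 5-fluoro-2-methoxyphenyl in place of 2-hydroxy-3-methoxyphenyl on a saturated chain carbon bound to an amine nitrogen. For the measured compounds named here, since the only measured example of this change left the read-out essentially where it was, the step expected here is small, estimated at a 1.0-fold higher number from compound 3 to compound 4 (0.01 log units; within the scatter), resting on no change at the digits printed from compound 2 to compound 1 (within the scatter). For compound 4 the estimated value in this assay is 240 10^-6 cm/s, with a likely range from 130 10^-6 cm/s to 450 10^-6 cm/s.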

Compound 4, apparent permeability: 237 10^-6 cm/s
Estimate against measurement, compound 4: 1.0-fold (0.01 log units) above; measured number inside the range.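

In this assay, putting 5-fluoro-2-methoxyphenyl in place of 2-hydroxy-3-methoxyphenyl gave no change at the digits printed from compound 3 to compound 4 (within the scatter) on the second core. Two cores and a single read-out are a small sample, so this does not show that the swap would stay as quiet on a third core or in a different kind of test. On these two cores, however, the change carried over with the same outcome: the same change on two cores in this assay, no change at the digits printed (within the scatter) from compound 2 to compound 1 and no change at the digits printed (within the scatter) from compound 3 to compound 4, 1.0-fold (0.00 log units) apart, within the scatter of two such steps

On these data alone, what stays open is whether a less similar group in this place, such as a carboxylic acid or a simple amine, or a longer chain, would shift the number at all. The compounds shown also say nothing about how this swap behaves in any other kind of test.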